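Replacing Dimethylamino in an Inactive Compound: What to Expect

This account rests on a few compounds, and the source may have more. Where it says the series, first, only, none or still open, it means among the compounds named here.

In a functional assay on HepG2 cells (Homo sapiens) for antiproliferative activity, read by MTT assay, with a stated time of 72 h (on this read-out higher numbers stand for weaker inhibition and lower numbers for stronger inhibition), compound 1 (`O=C(N/N=C/c1ccccc1)Nc1ccc(Oc2ccnc3[nH]ccc23)cc1`) gives 750 nM, and compound 2 (`COc1ccc(/C=N/NC(=O)Nc2ccc(Oc3ccnc4[nH]ccc34)cc2)cc1`) gives 9740 nM. That change, methoxy in place of hydrogen on an aromatic carbon, is a 13-fold higher number from compound 1 to compound 2 (1.11 log units; beyond the scatter), a large step beyond the scatter. Compound 3 (`CN(C)CCn1cccc1/C=N/NC(=O)Nc1ccc(Oc2ccnc3[nH]ccc23)cc1`) is reported as "not active" (no number reported), so it has no single number to start from.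

Compound 4 (`CN1CCN(CCCn2cccc2/C=N/NC(=O)Nc2ccc(Oc3ccnc4[nH]ccc34)cc2)CC1`) differs from compound 3 in one place, on a saturated chain carbon, two bonds along the chain from an aromatic nitrogen: (4-methylpiperazin-1-yl)methyl in place of dimethylamino on a saturated chain carbon, two bonds along the chain from an aromatic nitrogen. In words, (4-methylpiperazin-1-yl)methyl stands in place of dimethylamino.

Among the measured compounds shown here, no measured step covers this change. For the measured compounds named here, the methoxy step of a 13-fold higher number from compound 1 to compound 2 (1.11 log units; beyond the scatter) shows only that a single change can move the number a long way, so the size of this step cannot be stated. Compound 3, at "not active" (no number reported), is the closest guide, and it points to weak inhibition in this assay, possibly again without a number. If a number is reported, compound 4 is expected near 15000 nM, with an estimated range of 3000 nM to 70000 nM.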

Compound 4, half-maximal inhibitory concentration: 2760 nM
Compound 4: the middle estimate sits 5.4-fold (0.74 log units) above what was measured, outside the stated range (below it).
By their numbers in this assay, from the lowest: compound 1; then compound 4; then compound 2.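

Among the compounds shown here, compound 3 has no number in this assay, so although compound 4 gives 2760 nM no step between the two can be read. Nothing measured here explains this result. The compounds shown leave open how much the 3-(4-methylpiperazin-1-yl)propyl group itself moves the number.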